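The source may hold more compounds than are shown below. What is called first, only, known or untested is meant among the compounds shown, and "the series" means these compounds.

Measured so far in a functional assay on cells for antagonist activity at C-X-C chemokine receptor type 4 (Homo sapiens), read by fluorescence and calcium flux, with stated times of 25 min and 90 s; on this read-out higher numbers stand for weaker inhibition and lower numbers for stronger inhibition:
compound 1 `c1ccc2c(c1)CN[C@@H](CN(CCCCNCC1CCNCC1)[C@H]1CCCc3cccnc31)C2`: 36.5 nM
compound 2 `c1ccc2c(c1)CN[C@@H](CN(CCCCNCC1CCSCC1)[C@H]1CCCc3cccnc31)C2`: 69.6 nM
compound 3 `c1ccc2c(c1)CN[C@@H](CN(CCCCNC1CCCCC1)[C@H]1CCCc3cccnc31)C2`: 75.2 nM

Compound 3 gives the highest number of the three; compound 2 sits within the scatter of it, while the gap to compound 1, a 2.1-fold higher number from compound 1 to compound 3 (0.31 log units; beyond the scatter), is modest and beyond the scatter. The other steps, a 1.9-fold higher number from compound 1 to compound 2 (0.28 log units; within the scatter) and a 1.1-fold higher number from compound 2 to compound 3 (0.03 log units; within the scatter), are both within the scatter, so variation of the terminal amine group has so far moved this assay little.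

Compound 4 `NCc1cccc(CN(C[C@H]2Cc3ccccc3CN2)[C@H]2CCCc3cccnc32)c1` carries a different change: 3-(aminomethyl)phenyl in place of 3-(cyclohexylamino)propyl on a saturated chain carbon bound to an amine nitrogen. Among the compounds with values here, no measured step covers a chain-to-aromatic exchange of this kind, so the three steps bear on it only loosely; given their small size, the expected step of a 1.1-fold higher number from compound 3 to compound 4 (0.03 log units; within the scatter) is set near no change, with a wide range.

Compound 4 is therefore expected to give 80 nM in this assay, within 25 nM to 250 nM.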

Compound 4, half-maximal inhibitory concentration: 292 nM
Estimate against measurement, compound 4: 3.7-fold (0.56 log units) below, and the stated range ends below it.
By their numbers in this assay, from the lowest: compounds 1, 2 and 3 (each within the scatter of the next, the first and the last beyond it); then compound 4.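

In this assay, the exchange to 3-(aminomethyl)phenyl on a saturated chain carbon bound to an amine nitrogen gives larger steps than any seen among the first three compounds (a 3.9-fold higher number from compound 3 to compound 4 (0.59 log units; beyond the scatter)) (a 4.2-fold higher number from compound 2 to compound 4 (0.62 log units; beyond the scatter)) (an 8.0-fold higher number from compound 1 to compound 4 (0.90 log units; beyond the scatter)). This place is therefore not indifferent to its substituent: compound 4, with its six-membered aromatic ring of carbon, has the highest number of the series. No supporting measurement bears on why this step is so large.

From the compounds shown here alone, whether the aromatic ring or the loss of the chain carries the change stays open. Both 3-(aminomethyl)cyclohexyl and 3-(2-aminoethyl)phenyl at this place would bear on that question.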